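Swapping the Aryl Group on the Ring Nitrogen

This account rests on a few compounds, and the source may have more. Where it says the series, first, only, none or still open, it means among the compounds named here.

Three compounds were measured in a functional assay on 143B cells (Homo sapiens) for inhibition, read by CCK-8 assay, with a stated time of 72 h, tested at 1 uM; a higher number here means more inhibition at the concentration tested (going by the name of the read-out), a lower number less inhibition. Compound 1 `COc1ccc(C)cc1N1C(=O)CSC1c1cccc(C(=O)NCCCCc2ccccc2)c1` gives 29% in this assay. Compound 3 `COc1ccccc1N1C(=O)CSC1C(=O)NCCCCc1ccccc1` gives 4% in this assay, and compound 2 `O=C(NCCCCc1ccccc1)c1cccc(C2OCC(=O)N2c2cccc(F)c2)c1` gives 0%. Compound 1 stands highest of the three, and its gap to compound 3 and to compound 2 lies beyond the scatter in both cases. Among the measured compounds shown here, no step between measured compounds that differ in one place is available, so the effect of exchanging the group on the amide-type nitrogen in the ring has not been observed directly. Compound 4 `CC(F)(F)c1cccc(N2C(=O)CSC2c2cccc(C(=O)NCCCCc3ccccc3)c2)c1` is the one not yet measured. It differs from compound 1 in this way: a group of 10 heavy atoms (8 carbon, 2 fluorine; one six-membered aromatic ring of carbon only) in place of a group of 9 heavy atoms (8 carbon, 1 oxygen; one six-membered aromatic ring of carbon only), on an amide-type nitrogen in a ring. Nothing in the measured set shows how such an exchange shifts the read-out, so the expectation is a step of modest size, with its direction uncertain. The estimate for compound 4 in this assay is therefore 25%, expected to fall between 5% and 50%. The expected step of a number 4 percentage points lower from compound 1 to compound 4 (within the scatter) is accordingly judged small, likely within the scatter.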

Compound 4, a percentage reported as inhibition, at one concentration (the size of the read-out at that concentration, not a potency): 1%
For compound 4 the middle estimate is 24 percentage points above the measured one; measured number outside the range, below it.
By their numbers in this assay, from the lowest: compounds 2, 4 and 3 (each within the scatter of the next); then compound 1.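

Exchanging the 2-methoxy-5-methylphenyl group on the amide-type nitrogen in the ring for the fluorine-bearing group of compound 4 gives, in this assay, a number 28 percentage points lower from compound 1 to compound 4 (beyond the scatter) with the rest of the molecule unchanged. Among the compounds shown here, this is the first direct sign that the read-out depends on the group at this position: the shared core and the amide side chain of compound 1 do not keep the inhibition on their own. Nothing available bears on why the read-out changes with this exchange.

The compounds shown leave open whether the methoxy group, the methyl group or both matter on this ring. They also leave open how a plain phenyl, or an aryl group carrying an amine or a carboxylic acid, would read at this nitrogen.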